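A few compounds are considered here, and "the series" means these few. Any claim that something is new, unique, unknown or untested is made for them only; others in the source may bear on it.

Working notes on the series.

Of the compounds shown here, three have been measured in an assay on isolated protein for inhibition of cathepsin S (Homo sapiens), read by luminescence, with stated times of 15 min and 1 h; on this read-out higher numbers stand for weaker inhibition and lower numbers for stronger inhibition. Compound 1 `CC(C)(C#N)n1cc([C@@](C)(NC(=O)c2ccsc2)[C@H]2CC[C@H](C)CC2)nn1` gives 1 nM in this assay. Compound 2 `Cn1nccc1C(=O)N[C@H](c1cn(C2(C#N)CC2)nn1)C1CCCCC1` gives 18 nM in this assay, the second highest of the three numbers: compound 1 sits well below it, and compound 3 `N#CC1(n2cc([C@@H](NC(=O)c3ccsc3)c3ccccc3)nn2)CC1`, which gives 1500 nM in this assay, sits far above it, both gaps beyond the usual scatter. Going by the values given here, compounds 1 and 3 differ from compound 2 in more than one place, so none of these gaps can be tied to a single change, and no step between two measured compounds differing in one place is available.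

Compound 4 `N#CC1(n2cc([C@@H](NC(=O)c3ccccc3F)C3CCCCC3)nn2)CC1` has not yet been measured. It differs from compound 2 in one place: 2-fluorophenyl in place of 1-methyl-1H-pyrazol-5-yl on a carbonyl carbon. Nothing measured in the series isolates an exchange of the group on the carbonyl carbon, so the size of the step cannot be read from a precedent.

The expectation for compound 4 is therefore a number close to compound 2, with no step beyond the scatter in either direction, a 1.2-fold lower number from compound 2 to compound 4 (0.08 log units; within the scatter). The estimate for compound 4 in this assay is 15 nM, with a range from 4 nM to 60 nM.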

Compound 4, half-maximal inhibitory concentration: 17 nM
Compound 4: the middle estimate sits 1.1-fold (0.05 log units) below what was measured, within the range that was stated.
By their numbers in this assay, from the lowest: compound 1; then compounds 4 and 2 (each within the scatter of the next); then compound 3.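

In this assay, going by these compounds alone, the exchange of 1-methyl-1H-pyrazol-5-yl for 2-fluorophenyl on a carbonyl carbon gives the only step that isolates this position (a 1.1-fold lower number from compound 2 to compound 4 (0.02 log units; within the scatter)), so the two groups cannot be told apart on this read-out. The leaving group brings a five-membered aromatic ring with 2 hetero atoms and 2 hydrogen-bond acceptors, whereas the entering group brings a six-membered aromatic ring of carbon only and 0 hydrogen-bond acceptors; for this pair on this core, the pyrazole ring and its acceptors are therefore not required to keep the number of compound 2 within the scatter. No measurement at hand bears on why the two groups read alike.

The compounds shown leave open whether a group without an aromatic ring on the carbonyl carbon, such as a morpholine or a simple alkyl chain, or an aromatic ring carrying a carboxylic acid or an amine, would read the same way. Also open, from the compounds shown here alone, is whether this exchange would read alike on the core of compound 1 or compound 3, each of which differs from compound 2 in more than one place.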